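Methoxy for trifluoromethyl on the pyridyl-substituted bicyclic amine

A few compounds are considered here, and "the series" means these few. Any claim that something is new, unique, unknown or untested is made for them only; others in the source may bear on it.

Measured so far:
compound 1, `C1=C(c2cncnc2)CC2CNCC1C2`, 0.2 nM
compound 2, `COc1ccc(C2=CC3CC(C2)CN(C)C3)cn1`, 797 nM
compound 3, `FC(F)(F)c1cncc(C2=CC3CNCC(C2)C3)c1`, 0.7 nM

In an in vitro assay on SH-EP1 cells for displacement of a labelled ligand from Neuronal acetylcholine receptor; alpha4/beta2 (Homo sapiens) (on this read-out higher numbers stand for weaker inhibition and lower numbers for stronger inhibition), compound 3 stands second highest of the three numbers. Its nearest neighbour is compound 1 with 0.2 nM, a gap beyond the scatter; furthest away is compound 2 with 797 nM, a large gap also beyond the scatter. Compound 2 differs from compound 3 in several places at once, so its number says nothing clean about any single group.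

Compound 4, `COc1cncc(C2=CC3CNCC(C2)C3)c1`, is not yet measured. It differs from compound 3 in one place: methoxy in place of trifluoromethyl on an aromatic carbon. Among the measured compounds shown here, no step between measured compounds shows this exchange on this core, so the direction rests on the shape of the series alone. Both substituted pyridyl compounds measured with a free amine sit low in this assay, and the expectation is that the number shifts only modestly, with the methoxy compound somewhat weaker than the trifluoromethyl one, as a 2.9-fold higher number from compound 3 to compound 4 (0.46 log units; beyond the scatter). Compound 4 is therefore estimated at 2 nM, in the range 0.5 nM to 10 nM.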

Compound 4, inhibition constant: 0.3 nM
For compound 4 the middle estimate is 6.7-fold (0.82 log units) above the measured one; the whole stated range lies above it.
By their numbers in this assay, from the lowest: compounds 1 and 4 (each within the scatter of the next); then compound 3; then compound 2.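

In this assay methoxy in place of trifluoromethyl gives a 2.3-fold lower number from compound 3 to compound 4 (0.37 log units; beyond the scatter), a modest step beyond the scatter. This aromatic carbon, two atoms from the ring nitrogen, therefore accepts methoxy with no loss of inhibition, and the number moves towards stronger inhibition. The earlier compounds shown here could not show this, since compound 2 differs from compound 3 in several places at once. Nothing available explains the step.

Going by these compounds, whether a nitrile, an amine or a hydroxyl group at this carbon would also keep the number low stays open. Also open, on these data alone, is whether the much weaker inhibition of compound 2 at 797 nM comes from the methyl on its amine or from where its methoxy sits.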